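Swapping a Fluoro Group for Hydrogen on Compound 2

The compounds below may be only part of what the source reports. "The series", "measured", "known", "first", "only" and "open" are said of these compounds alone.

Measured in a physicochemical assay for lipophilicity, read by HPLC, measured as chromatographic lipophilicity, at pH 7.4; a lower number here means a more polar compound, a higher number a more lipophilic compound:
Compound 1 `CC(=O)N1CCC(C(=O)N2N=CCC2c2ccccc2)CC1` gives 2.5
Compound 2 `CC(C)(C)C(=O)N1N=CCC1c1cc(F)cc(F)c1` gives 6.3
Compound 3 `O=C(c1cn[nH]c1)N1CCC(C(=O)N2N=CCC2c2ccccc2)CC1` gives 2.1

Compound 2 stands highest of the three, far beyond both compound 1 and compound 3. Compound 4 `CC(C)(C)C(=O)N1N=CCC1c1cccc(F)c1` is not yet measured and differs from compound 2 by one change hydrogen in place of fluoro on an aromatic carbon that puts hydrogen in place of fluoro on an aromatic carbon. Going by the values given here, the only measured step is a number 0.40 log units lower from compound 1 to compound 3 (beyond the scatter) and it swaps a different group at a different place, so it offers only a weak guide. A small drop is expected from the value of compound 2 at 6.3 in this assay here. The expected step is a number 0.30 log units lower from compound 2 to compound 4 (within the scatter) and that would be a small one. For compound 4 the estimated value is 6 with an expected range from 5.6 to 6.3 in this measurement.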

Compound 4, distribution coefficient: 5.9
Estimate against measurement, compound 4: 0.10 log units above; the range from low to high includes it.
By their numbers in this assay, from the lowest: compound 3; then compound 1; then compound 4; then compound 2.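

In this assay, going by these compounds alone, the earlier compounds gave no reading at this aromatic carbon, and hydrogen in place of fluoro now supplies the first (a number 0.40 log units lower from compound 2 to compound 4 (beyond the scatter)). The step lies beyond the usual scatter, so this single-atom change registers in the measurement, at least for this pair. Nothing measured here explains why the number moves. On these data alone, whether replacing the remaining fluoro group with hydrogen would give a similar step stays open. So does what a chlorine, a methoxy group or an amine would do on this aromatic carbon.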